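The compounds below may be only part of what the source reports. "The series", "measured", "known", "first", "only" and "open" are said of these compounds alone.

In a functional assay on MCF7 cells (Homo sapiens) for cytotoxicity, read by WST assay, with a stated time of 72 h (on this read-out higher numbers stand for weaker inhibition and lower numbers for stronger inhibition), compound 1 (`O=C1Nc2c(ccc(F)c2F)C1(c1ccccc1)c1ccc(O)cc1`) gives 7.1 nM, compound 2 (`O=C1Nc2c(ccc(F)c2F)C1(c1ccc(O)cc1)c1ccc(F)cc1`) gives 2.6 nM and compound 3 (`O=C1Nc2c(ccc(F)c2F)C1(c1ccc(O)cc1)c1cccs1`) gives 82 nM. Compound 3 therefore has the highest number of the three and is the weakest inhibitor measured so far. Compound 4 (`O=C1Nc2c(ccc(F)c2F)C1(c1ccc(O)cc1)C1CCCCCCC1`) keeps the core of compound 3 but carries cyclooctyl in place of thiophen-2-yl on a saturated ring carbon.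

Two measured steps involve this same carbon. They are a 12-fold higher number from compound 1 to compound 3 (1.06 log units; beyond the scatter) and a 32-fold higher number from compound 2 to compound 3 (1.50 log units; beyond the scatter), and both are large. Each puts thiophen-2-yl where phenyl or 4-fluorophenyl stood, so the number clearly responds to the group at this place. The remaining step, a 2.7-fold lower number from compound 1 to compound 2 (0.44 log units; beyond the scatter), is modest and comes from fluoro in place of hydrogen on an aromatic carbon, so it offers less guidance here. For the measured compounds named here, no measured compound has a non-aromatic ring at this carbon, which makes any forecast uncertain. Since compound 3 sits at the high end, a move toward a lower number seems more likely than a further rise, though probably a smaller move than those large steps. The expected change is a 2.7-fold lower number from compound 3 to compound 4 (0.44 log units; beyond the scatter). For compound 4, the estimated value in this assay is 30 nM, with an expected range from 4 nM to 250 nM.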

Compound 4, half-maximal inhibitory concentration: > 1000 nM
Compound 4 ended at the assay's limit; the forecaster's own chance of this, stated with the estimate: 3%; middle value at least 33-fold (1.52 log units) from the limit.
By their numbers in this assay, from the lowest: compound 2; then compound 1; then compound 3. At a limit, above all of these: compound 4.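

In this assay compound 4 gives > 1000 nM, which is a limit of the assay and not a number: the limit of > 1000 nM in this assay, at which 1 of the 4 values shown sits.

Up to now every group on this saturated ring carbon was aromatic, and every compound gave a measurable number; cyclooctyl, the first non-aromatic ring here, brings an at least 12-fold higher number from compound 3 to compound 4 (1.08 log units; beyond the scatter), along with an at least 380-fold higher number from compound 2 to compound 4 (2.58 log units; beyond the scatter) and an at least 140-fold higher number from compound 1 to compound 4 (2.14 log units; beyond the scatter), all of them large. Even thiophen-2-yl, which gave the highest number among the aromatic groups, stays within the measurable range, so the differences among those groups cover only part of how far the number can move with a change at this carbon.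

Cyclooctyl differs from the three aromatic groups both in its ring size and in not being aromatic, and the compounds shown do not separate these two changes. Going by these compounds, whether a smaller non-aromatic ring such as cyclopentyl, or an open chain such as butyl, would keep a measurable number at this carbon also stays open.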